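The source may report more compounds than this note shows. Statements on the series, on what has been measured and on what is new or still open speak of the compounds shown alone.

Among the measured compounds shown here, compound 1 `O=S(=O)(c1ccccc1Cl)n1cc(C2=CCNCC2)c2ccccc21` gives 0.4 nM in an assay on HeLa cells for binding affinity to 5-hydroxytryptamine receptor 6 (Homo sapiens) (on this read-out higher numbers stand for weaker inhibition and lower numbers for stronger inhibition), the lower of the two numbers recorded here; compound 2 `Nc1ccc(S(=O)(=O)n2cc(C3=CCNCC3)c3ccc([N+](=O)[O-])cc32)cc1` gives 31 nM in this assay, a far higher number, though the two differ in more than one place and no single step links them. Compound 3 `CCCCS(=O)(=O)n1cc(C2=CCNCC2)c2ccccc21` is not yet measured. It differs from compound 1 by butyl in place of 2-chlorophenyl on a sulfonyl sulfur. For the measured compounds named here, with no comparable step among the measured compounds, the expected step from compound 1 to compound 3 is a 25-fold higher number from compound 1 to compound 3 (1.40 log units; beyond the scatter), an upward move beyond the scatter. Compound 3 is thus estimated at 10 nM, within a range of 2 nM to 60 nM.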

Compound 3, inhibition constant: 77 nM
Compound 3: middle estimate off by 7.7-fold (0.89 log units), on the low side, and the stated range ends below it.
By their numbers in this assay, from the lowest: compound 1; then compound 2; then compound 3.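

Butyl in place of 2-chlorophenyl on a sulfonyl sulfur gives a 190-fold higher number from compound 1 to compound 3 (2.28 log units; beyond the scatter) in this assay. Among the compounds shown here, this is the first step that changes this position alone, and it shows that the read-out depends strongly on the group held there, which the comparison of compound 1 with compound 2 could not isolate. From the compounds shown here alone, what remains open is whether phenyl without the chlorine, a longer chain or an amine on the sulfonyl sulfur would bring the number back towards that of compound 1. Nothing measured here accounts for the size of this step.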